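The source may report more compounds than this note shows. Statements on the series, on what has been measured and on what is new or still open speak of the compounds shown alone.

Measured so far:
- compound 1, `CC[C@H]1OC(=O)[C@H](C)[C@@H](O[C@H]2C[C@@](C)(OC)[C@@H](O)[C@H](C)O2)[C@H](C)[C@@H](O[C@@H]2O[C@H](C)C[C@H](N(C)C)[C@H]2O)[C@](C)(O)C[C@@H](C)CN(CCCNC(=O)C2CCC2)[C@H](C)[C@@H](O)[C@]1(C)O`: 2.31
- compound 2, `CCCCCCCC(=O)NCCCN1C[C@H](C)C[C@@](C)(O)[C@H](O[C@@H]2O[C@H](C)C[C@H](N(C)C)[C@H]2O)[C@@H](C)[C@H](O[C@H]2C[C@@](C)(OC)[C@@H](O)[C@H](C)O2)[C@@H](C)C(=O)O[C@H](CC)[C@@](C)(O)[C@H](O)[C@H]1C`: 3.74
- compound 3, `CC[C@H]1OC(=O)[C@H](C)[C@@H](O[C@H]2C[C@@](C)(OC)[C@@H](O)[C@H](C)O2)[C@H](C)[C@@H](O[C@@H]2O[C@H](C)C[C@H](N(C)C)[C@H]2O)[C@](C)(O)C[C@@H](C)CN(C)[C@H](C)[C@@H](OCCCNC(=O)C2CCC2)[C@]1(C)O`: 3.5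

In a physicochemical assay for lipophilicity, read by HPLC, measured as chromatographic lipophilicity, at pH 7.4 (a lower number here means a more polar compound, a higher number a more lipophilic compound), compound 1 gives 2.31 and compound 2 gives 3.74. The change between the two is heptyl in place of cyclobutyl on a carbonyl carbon, and the step it made reads a number 1.43 log units higher from compound 1 to compound 2 (beyond the scatter). Compound 3 gives 3.5 in this assay; against compound 1 this is higher, beyond the scatter, while against compound 2 the two values lie within the scatter and no order is drawn between them. The core of compound 3 differs from the core of compound 1 in more than one place, and the difference between the two cores is not broken down here.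

Compound 4, `CCCCCCCC(=O)NCCCO[C@@H]1[C@@H](C)N(C)C[C@H](C)C[C@@](C)(O)[C@H](O[C@@H]2O[C@H](C)C[C@H](N(C)C)[C@H]2O)[C@@H](C)[C@H](O[C@H]2C[C@@](C)(OC)[C@@H](O)[C@H](C)O2)[C@@H](C)C(=O)O[C@H](CC)[C@@]1(C)O`, is not yet measured. It stands to compound 3 as compound 2 stands to compound 1: heptyl in place of cyclobutyl on a carbonyl carbon. The place is the same word for word in both pairs, so this is the same change, occurring in two pairs in all. Beside a number 1.43 log units higher from compound 1 to compound 2 (beyond the scatter), the step expected is a number 1.40 log units higher from compound 3 to compound 4 (beyond the scatter), because a number 1.43 log units higher from compound 1 to compound 2 (beyond the scatter) is the only measured instance of this change and nothing in the data says it should read differently on the core of compound 3. Compound 4 is therefore estimated at 4.9, with an expected range from 4.4 to 5.4.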

Compound 4, distribution coefficient: 5.18
For compound 4 the middle estimate is 0.28 log units below the measured one; low and high end bracket the measured number.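

In this assay the exchange of cyclobutyl for heptyl on a carbonyl carbon whose other neighbour is an amide-type nitrogen reads a number 1.68 log units higher from compound 3 to compound 4 (beyond the scatter) and, on the other core, a number 1.43 log units higher from compound 1 to compound 2 (beyond the scatter); both steps are large and run the same way. These two pairs show that the change carried from one core to the other in direction and in large size, but they do not show that it would carry the same way to any further core in the series. No measurement given here bears on why the step reads as it does.

The compounds shown hold only cyclobutyl and heptyl at this carbonyl carbon, so it remains open how a chain longer than heptyl, or a group carrying an amine or a carboxylic acid, would read in this assay on either core. On these data alone, the cores of compound 1 and compound 3 differ in more than one place, so which of those differences matters for this read-out also remains open.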